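Loss of the aryl group on the bridged amine core

The compounds below may be only part of what the source reports. "The series", "measured", "known", "first", "only" and "open" are said of these compounds alone.

Measured so far:
compound 1 `Clc1ccc(C2C3CCC2CN(Cc2ccccc2)C3)cc1` — 601 nM
compound 2 `CN1CC2CCC(C1)C2c1ccccc1` — 1040 nM

Two compounds of the series have numbers in an assay on a subcellular fraction from brain for binding affinity to sodium-dependent dopamine transporter (Rattus norvegicus); on this read-out higher numbers stand for weaker inhibition and lower numbers for stronger inhibition. Compound 1 gives 601 nM in this assay, and compound 2 gives 1040 nM; the two values lie within the scatter of each other, so neither can be set apart from the other on this read-out. Among the measured compounds shown here, compound 1 carries a 4-chlorophenyl on the saturated ring carbon of its core, while compound 2 carries a plain phenyl on a related core; no single-point step between them is available, so the pair only shows two comparable values.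

Compound 3 `OC1C2CCC1CN(Cc1ccccc1)C2` has not been measured. It differs from compound 1 by hydroxy in place of 4-chlorophenyl on a saturated ring carbon. For the measured compounds named here, no measured step of this kind exists. Going by the values given here, the expectation is that the step from compound 1 to compound 3 in this assay is a large rise in the number, well beyond the scatter, since the 4-chlorophenyl that leaves is the only aryl group on the core of compound 1, which gives 601 nM. The estimated step is a 50-fold higher number from compound 1 to compound 3 (1.70 log units; beyond the scatter). Compound 3 is therefore expected at about 30000 nM, with a range from 5000 nM to 200000 nM, and a limit value rather than a number is a real possibility.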

Compound 3, half-maximal inhibitory concentration: 45000 nM
Compound 3: middle estimate off by 1.5-fold (0.18 log units), on the low side; the measured number falls inside the stated range.
By their numbers in this assay, from the lowest: compounds 1 and 2 (each within the scatter of the next); then compound 3.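

In this assay, among the compounds shown here, the exchange of 4-chlorophenyl for hydroxy on a saturated ring carbon gives a 75-fold higher number from compound 1 to compound 3 (1.87 log units; beyond the scatter) and is the first change confined to a single place, which the earlier pair could not provide. This position therefore has a large bearing on the read-out: everything else in compound 1 is kept in compound 3, and that retained structure alone does not preserve the value of compound 1. The step is a single exchange in which the aryl group leaves and hydroxy enters together, and no independent data bear on why it is this large.

Still open, on these data alone, is how the step divides between losing the 4-chlorophenyl and gaining the hydroxy; a methoxy or an amine on the same saturated ring carbon would help separate the two contributions. For the compounds shown here, also open is what the chlorine itself contributes, since compound 1 and compound 2 differ in more than one place and give no step for it, so a comparison with plain phenyl on the core of compound 1 remains to be read.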